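This account rests on a few compounds, and the source may have more. Where it says the series, first, only, none or still open, it means among the compounds named here.

Compound 1 `O=C1CSc2ccc(NC(=O)C3CCN(c4cc(F)c(F)c(F)c4)CC3)cc2N1`: 1960 nM
Compound 2 `O=C1COc2ccc(NC(=O)C3CCN(c4cccc(Cl)c4)CC3)cc2N1`: 190 nM
Compound 3 `CCOC(=O)C1(C)Oc2ccc(NC(=O)C3CCN(c4cc(F)c(F)c(F)c4)CC3)cc2NC1=O`: 870 nM

Three compounds have so far been run in a functional assay for antagonist activity at transient receptor potential cation channel subfamily V member 1 (Homo sapiens), read by FLIPR and calcium flux; on this read-out lower numbers stand for stronger inhibition and higher numbers for weaker inhibition. Compound 1 gives 1960 nM, compound 3 gives 870 nM, and compound 2 gives 190 nM, the lowest of the three numbers. The gap from compound 2 to compound 3 lies beyond the usual scatter, and the gap to compound 1 is wider still, so compound 2 is the strongest inhibitor among the measured set. None of these three pairs differs in only one place, so the data say nothing about which part of the structure accounts for those gaps.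

Compound 4 `COc1cccc(N2CCC(C(=O)Nc3ccc4c(c3)NC(=O)CO4)CC2)c1` has not yet been measured. It shares the core of compound 2 and departs from it in a single spot: methoxy in place of chloro on an aromatic carbon. Going by the values given here, no measured pair shows the effect of this exchange, so the expectation rests only on the value of compound 2 and the general experience that such a swap rarely moves this kind of read-out far.

Compound 4 is therefore estimated to give about 450 nM, within a range from 150 nM to 1500 nM. The expected step of a 2.4-fold higher number from compound 2 to compound 4 (0.37 log units; beyond the scatter) is small, toward a somewhat higher number, and may well stay within the scatter.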

Compound 4, half-maximal inhibitory concentration: 1420 nM
The estimate for compound 4 lay 3.2-fold (0.50 log units) below the measured number, and the stated range covers the measured number.
By their numbers in this assay, from the lowest: compound 2; then compounds 3, 4 and 1 (each within the scatter of the next, the first and the last beyond it).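

In this assay, going by these compounds alone, replacing chloro with methoxy on the aromatic carbon meta to a large group gives a 7.5-fold higher number from compound 2 to compound 4 (0.87 log units; beyond the scatter) and so provides the first comparison in the set that isolates a single change. Going from 3-chlorophenyl to 3-methoxyphenyl on an otherwise unchanged structure weakens inhibition by more than the scatter, which shows that the read-out responds to what this position carries and that chloro is the better of these two groups here. Nothing available bears on why this exchange has such an effect. Within the data shown here, this single pair gives only one exchange at one position, so it sets no general order among substituents.

From the compounds shown here alone, whether a methyl, a trifluoromethyl or a nitrile at the same place would read closer to compound 2 or to compound 4 remains open, as does the result with a hydroxyl or an amine there. Also open, going by these compounds, is whether the same exchange would produce a step of similar size on the core of compound 1, which carries a sulfur in its ring.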